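Aryl swap on the octadecyl amide of the series

The compounds below may be only part of what the source reports. "The series", "measured", "known", "first", "only" and "open" are said of these compounds alone.

Measured so far:
Compound 1, `CCCCCCCCCCCCCCNC(=O)[C@@H](NC(=O)c1nccc2ccccc12)[C@@H](C)O`: in a functional assay on A-431 cells (Homo sapiens) for cytotoxicity, read by MTT assay, with a stated time of 48 h (a higher number here means a weaker inhibitor, a lower number a stronger inhibitor), compound 1 gives 23000 nM.
Compound 2, `CCCCCCCCCCCCCCCCCCNC(=O)[C@@H](NC(=O)c1ccccc1)[C@@H](C)O`: in this assay compound 2 gives 113000 nM.

Among the compounds with values here, compound 2 stands at the higher of the two numbers; its nearest neighbour is compound 1, and that gap is beyond the scatter, but the two differ in both the chain and the aryl group, so no single step is known. Compound 3, `CCCCCCCCCCCCCCCCCCNC(=O)[C@@H](NC(=O)c1nccc2ccccc12)[C@@H](C)O`, keeps the chain of compound 2 and carries isoquinolin-1-yl in place of phenyl on a carbonyl carbon. Because compound 1 with the same aryl group gives 23000 nM, a lower number is expected. The expected step is a 3.2-fold lower number from compound 2 to compound 3 (0.51 log units; beyond the scatter), beyond the scatter. Compound 3 is estimated at 35000 nM (range 12000 nM to 110000 nM).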

Compound 3, half-maximal inhibitory concentration: 44100 nM
Beside the measured number, compound 3's estimate is 1.3-fold (0.10 log units) below it; the range from low to high includes it.
By their numbers in this assay, from the lowest: compounds 1 and 3 (each within the scatter of the next); then compound 2.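

Within the data shown here, on the octadecyl amide, isoquinolin-1-yl in place of phenyl on a carbonyl carbon gives the first readable step at this position in this assay: a 2.6-fold lower number from compound 2 to compound 3 (0.41 log units; beyond the scatter), a modest step. Butyl in place of hydrogen on a saturated chain carbon gives a 1.9-fold higher number from compound 1 to compound 3 (0.28 log units; within the scatter), so between these two chains the number does not separate. No measured evidence accounts for the aryl step.

Going by these compounds, whether the ring nitrogen matters remains open, since a naphthyl group on the same carbonyl carbon would be needed to test it. Also open, on these data alone, is how a much shorter chain, such as octyl, would read.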